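Swapping the biaryl of compound 2 for a methyl ester

The source may hold more compounds than are shown below. What is called first, only, known or untested is meant among the compounds shown, and "the series" means these compounds.

Measured compounds in a functional assay on DLD-1 cells (Homo sapiens) for antiproliferative activity, read by CellTiter-Glo, with a stated time of 72 h; on this read-out higher numbers stand for weaker inhibition and lower numbers for stronger inhibition:
- compound 1 `COc1ccccc1-c1cccc(S(=O)(=O)N2CCC(N3CCC(C)CC3)CC2)c1`: 21 nM
- compound 2 `CC1CCN(C2CCN(S(=O)(=O)c3ccc(-c4ccc(Cl)cc4)cc3)CC2)CC1`: 105 nM

Both compounds share the same sulfonamide-linked bipiperidine core and differ only in what sits on the aryl ring. In this assay compound 2 gives the higher of the two numbers, and its gap to compound 1 lies beyond the usual scatter of the measurement. Within the data shown here, the pair offers no single-point step that can be measured directly, so what the two values show is only that compound 1 and compound 2 are clearly apart.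

Compound 3 `COC(=O)c1ccc(S(=O)(=O)N2CCC(N3CCC(C)CC3)CC2)cc1` takes the step from compound 2 by the change (methoxycarbonyl in place of 4-chlorophenyl on an aromatic carbon). The aryl ring thus loses its distal ring altogether and carries a much smaller substituent in its stead. Among the measured compounds shown here, no measured step of this kind is available among the compounds here, so the direction rests on judgement alone.

Compound 3 is expected to show a step of a 4.3-fold higher number from compound 2 to compound 3 (0.63 log units; beyond the scatter) in this assay, towards a higher number. Compound 3 is therefore estimated at 450 nM, with a range from 110 nM to 2500 nM.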

Compound 3, half-maximal inhibitory concentration: > 5000 nM
Compound 3: no number, only a limit (the forecaster's own chance of this, stated with the estimate: 10%); middle value at least 11-fold (1.04 log units) away from the limit.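

Among these compounds, until now the two values could only be set apart, since compound 1 and compound 2 differ in more than one place; this pair gives the first change at a single place. In this assay the swap of 4-chlorophenyl for methoxycarbonyl, on an aromatic carbon para to a large group, gives an at least 47-fold higher number from compound 2 to compound 3 (1.67 log units; beyond the scatter) and so shows that the read-out is highly sensitive to what stands at this position, with the shared core left unchanged. Compound 3 reads > 5000 nM and that is a limit of the assay, not a number, so the step marks only a lower bound on the size of this change: the limit of > 5000 nM in this assay, at which 1 of the 3 values shown sits.

As far as these compounds go, the step changes the whole substituent at once, so it remains open whether the distal ring, its chlorine or the ester carbonyl accounts for the result. From the compounds shown here alone, how an unsubstituted phenyl, a methoxyphenyl at this same position, a carboxylic acid, a primary amide or a simple methyl would read in this assay remains open, as does whether any small group can stand here.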